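Sulfanyl compound 1 and its 4-fluorobenzyl analogue

This account rests on a few compounds, and the source may have more. Where it says the series, first, only, none or still open, it means among the compounds named here.

Measured in a functional assay on DU-145 cells (Homo sapiens) for inhibition, read by trypan blue exclusion, with a stated time of 96 h; a higher number here means a weaker inhibitor of growth, a lower number a stronger inhibitor of growth:
- compound 1 `CCOc1ccc(/C=C(/SCc2ccc(C)cc2)C(=O)c2ccc(Cl)cc2)cc1OC` gives 25000 nM
- compound 2 `COc1cc(OC)c(/C=C(\C(=O)c2ccc([N+](=O)[O-])cc2)S(=O)(=O)Cc2ccc(Cl)cc2)c(OC)c1` gives 10000 nM

Compound 1 holds the higher of the two numbers at 25000 nM, which makes it the weaker growth inhibitor here. Compound 2 at 10000 nM lies lower by more than the usual scatter. For the measured compounds named here, this gap is all that the pair shows, and no measured pair isolates a single change.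

Compound 3 `CCOc1ccc(/C=C(/SCc2ccc(F)cc2)C(=O)c2ccc(Cl)cc2)cc1OC` keeps the core of compound 1 and carries one change: fluoro in place of methyl on an aromatic carbon. This is fluoro in place of methyl on an aromatic carbon, para to a large group, so 4-methylbenzyl becomes 4-fluorobenzyl. Going by the values given here, with no measured step to guide it, the expectation starts from compound 1 at 25000 nM. No step beyond the scatter is expected in this assay, and neither direction has measured support. The expected change is a 1.3-fold lower number from compound 1 to compound 3 (0.10 log units; within the scatter), an estimate that stays within the scatter. Compound 3 is expected at 20000 nM, with an estimated range of 8000 nM to 45000 nM.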

Compound 3, concentration for 50% growth inhibition: 1000 nM
Compound 3: middle estimate off by 20-fold (1.30 log units), on the high side; measured number outside the range, below it.
By their numbers in this assay, from the lowest: compound 3; then compound 2; then compound 1.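

In this assay, for the compounds shown here, fluoro in place of methyl, on an aromatic carbon para to a large group, gives a 25-fold lower number from compound 1 to compound 3 (1.40 log units; beyond the scatter) and provides the only single-place step so far. The step shows that this place on the benzyl group of the sulfanyl series is sensitive: one heavy atom exchanged for another, with no change in ring count, hydrogen-bond donors, hydrogen-bond acceptors or net charge, moves the number well beyond the scatter. Nothing measured here accounts for the size of this step.

Whether the step is specific to fluoro remains open, since the compounds shown do not include the unsubstituted benzyl, 4-chlorobenzyl, 4-methoxybenzyl or 4-aminobenzyl analogues on the core of compound 1. It is also unresolved whether 4-fluorobenzyl would give a step of similar size in a sulfonyl analogue of compound 3, or with a 4-nitrophenyl ketone in place of the 4-chlorophenyl ketone.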